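The source may hold more compounds than are shown below. What is called first, only, known or untested is meant among the compounds shown, and "the series" means these compounds.

In a functional assay on HCT-116 cells (Homo sapiens) for antiproliferative activity, read by MTT assay, with a stated time of 72 h (a lower number here means a stronger inhibitor of growth, a higher number a weaker inhibitor of growth), compound 1 (`CCOc1cnc(CS(=O)(=O)/C=C/c2c(OC)cc(OC)cc2OC)cn1`) gives 1280 nM and compound 2 (`COc1ncc(C)cc1OC(C)=O`) gives 10 nM while compound 3 (`COc1cc(OC)c(/C=C/S(=O)(=O)Nc2ccc(Cl)nc2)c(OC)c1`) gives 5640 nM as the highest of the three numbers, beyond the scatter from both others. Compound 4 (`COc1cc(OC)c(/C=C/S(=O)(=O)Nc2cnc(Cl)cn2)c(OC)c1`) carries 5-chloropyrazin-2-yl in place of 6-chloropyridin-3-yl on a sulfonamide nitrogen and is otherwise the same as compound 3. No measured pair among these compounds shows such a swap, so the expectation rests on the structural change alone. In this assay the expected 1.4-fold lower number from compound 3 to compound 4 (0.15 log units; within the scatter) stays within the scatter, with no firm direction. The estimated value for compound 4 is 4000 nM and the expected range runs from 1200 nM to 12000 nM in this measurement.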

Compound 4, concentration for 50% growth inhibition: > 10000 nM
Compound 4: no number, only a limit; the forecaster's own chance of this, stated with the estimate: 10%; middle value at least 2.5-fold (0.39 log units) away from the limit.
By their numbers in this assay, from the lowest: compound 2; then compound 1; then compound 3. At a limit, above all of these: compound 4.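

In this assay compound 4 stands at > 10000 nM, which is a limit of the assay and not a number: the limit of > 10000 nM in this assay, at which 1 of the 4 values shown sits. Placing 5-chloropyrazin-2-yl in place of 6-chloropyridin-3-yl on a sulfonamide nitrogen gives an at least 1.7-fold higher number from compound 3 to compound 4 (0.24 log units; that floor lies within the scatter), the first reading of any swap at this position, and the added ring nitrogen brings no gain in growth inhibition. Going by these compounds, the size of any loss stays unknown, and the floor of this step does not by itself establish one. The compounds shown leave open what an amine or a methoxy group in place of the chlorine would do on either ring.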